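Esters of a bromovinyl nucleoside: removing the carbamate protecting group

The source may report more compounds than this note shows. Statements on the series, on what has been measured and on what is new or still open speak of the compounds shown alone.

Measured so far:
- compound 1, `CC(C)(C)OC(=O)NCCCC(=O)O[C@H]1[C@H](O)[C@@H](CO)O[C@H]1n1cc(/C=C/Br)c(=O)[nH]c1=O`: 55000 nM
- compound 2, `CC(C)(C)OC(=O)NCCCCCC(=O)O[C@H]1[C@H](O)[C@@H](CO)O[C@H]1n1cc(/C=C/Br)c(=O)[nH]c1=O`: 61000 nM

Compound 2 stands highest of the two numbers in an assay on isolated protein for inhibition of thymidine kinase 2, mitochondrial (Homo sapiens); a lower number here means a stronger inhibitor, a higher number a weaker inhibitor; its nearest neighbour is compound 1, with a 1.1-fold higher number from compound 1 to compound 2 (0.04 log units; within the scatter), so the two are indistinguishable within the scatter. Compound 3, `NCCCCCC(=O)O[C@H]1[C@H](O)[C@@H](CO)O[C@H]1n1cc(/C=C/Br)c(=O)[nH]c1=O`, differs from compound 2 by hydrogen in place of tert-butoxycarbonyl on an amine nitrogen. Among the compounds with values here, no measured step touches this position; the only step known, the chain extension from compound 1 to compound 2, lies within the scatter and gives no direction. For compound 3 a step of a 1.4-fold lower number from compound 2 to compound 3 (0.13 log units; within the scatter) is therefore expected, essentially no change beyond the scatter. The estimate for compound 3 in this assay is 45000 nM, in a range from 12000 nM to 170000 nM.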

Compound 3, half-maximal inhibitory concentration: > 500000 nM
Compound 3 was reported as a limit; the forecaster's own chance of this, stated with the estimate: 25%; middle value at least 11-fold (1.04 log units) from the limit.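

In this assay compound 3 stands only as a limit of the assay, not as a number: the limit of > 500000 nM in this assay, at which 1 of the 3 values shown sits. Hydrogen in place of tert-butoxycarbonyl on the amine nitrogen gives an at least 8.1-fold higher number from compound 2 to compound 3 (0.91 log units; beyond the scatter), so this position moves the read-out and the free amine is the weaker inhibitor, whereas the chain change alone gave no readable shift. The change measured against the shorter carbamate reads an at least 9.0-fold higher number from compound 1 to compound 3 (0.95 log units; beyond the scatter).

Open, going by these compounds, is whether a small acyl group on that nitrogen, such as an acetyl amide, stays near compound 1 and compound 2. Also open, on these data alone, is whether a free amine on the shorter chain of compound 1 behaves as compound 3 does.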